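Toxicity in THP-1 cells: from compound 3 to compound 4

A few compounds are considered here, and "the series" means these few. Any claim that something is new, unique, unknown or untested is made for them only; others in the source may bear on it.

Compound 1 `COc1ccc2nc(NC(=O)c3ccc(F)cc3)n(C)c2c1` gives > 100000 nM in a toxicity assay on THP-1 cells (Homo sapiens) for inhibition (on this read-out higher numbers stand for lower toxicity in this test and lower numbers for higher toxicity in this test), a limit of the assay.
Compound 2 `COc1ccc(-c2cnc(NC(=O)c3ccc([N+](=O)[O-])cc3)n2C)cc1` gives > 100000 nM in this assay, a limit of the assay.
Compound 3 `COc1ccc(C(=O)Nc2ncc(-c3ccc(OC)cc3)n2C)cc1` gives > 100000 nM in this assay, a limit of the assay.

Compound 3 stands at the limit of the assay, as do the two other measured compounds, so that the limit of > 100000 nM in this assay, at which 3 of the 3 values shown sit, holds for every value shown. The step from compound 2 to compound 3, a step that the two limits leave unreadable from compound 2 to compound 3, a methoxy in place of a nitro on an aromatic carbon, cannot be read in size, since both ends are limits.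

Compound 4 `COc1ccc(-c2cnc(NC(=O)c3ccccc3C)n2C)cc1` differs from compound 3 by 2-methylphenyl in place of 4-methoxyphenyl on a carbonyl carbon. Going by the values given here, the only measured step that touches this part of the molecule is the one from compound 2 to compound 3, and it gives no readable size. The three measured compounds therefore offer no evidence that any change on the aryl amide moves the read-out away from the limit, and no evidence that it does not.

For compound 4 the expected outcome in this assay is a value once more at or beyond the limit, 150000 nM, with a range of 40000 nM to 600000 nM, which means an expected step that the limit leaves unreadable from compound 3 to compound 4.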

Compound 4, half-maximal cytotoxic concentration: > 100000 nM
Compound 4: a limit, no number; the forecaster's own chance of this, stated with the estimate: 85%; the middle value is on the limit's open side.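

Compound 3 and compound 4 both stand at a limit in this assay and so no size can be read for the step between them, 2-methylphenyl in place of 4-methoxyphenyl on a carbonyl carbon. The compounds shown leave open whether any change in structure would bring a measurable value in this assay since every value remains a limit: the limit of > 100000 nM in this assay, at which 4 of the 4 values shown sit.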